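Replacing Chloromethyl with a Pyrrolidine Amide on a Macrocycle

The compounds below may be only part of what the source reports. "The series", "measured", "known", "first", "only" and "open" are said of these compounds alone.

Measured compounds:
compound 1 `CC(C)=CCC[C@]1(C)/C=C/[C@@H](OC(=O)C=C(C)C)[C@](C)(O)/C=C/C(=O)/C(CCl)=C\C1`, 390 nM
compound 2 `CC(C)=CCC[C@]1(C)/C=C/[C@@H](OC(=O)C=C(C)C)[C@](C)(O)/C=C/C(O)/C(C=O)=C\C1`, 1430 nM

In a functional assay on SW480 cells (Homo sapiens) for antiproliferative activity, read by MTT assay, with a stated time of 48 h (a higher number here means a weaker inhibitor, a lower number a stronger inhibitor), compound 1 gives 390 nM, the lowest of the two numbers and therefore the stronger of the two inhibitors. Compound 2 gives 1430 nM, a higher number beyond the usual scatter, so the two values stand apart. Compound 3 `CC(C)=CCC[C@]1(C)/C=C/[C@@H](OC(=O)C=C(C)C)[C@](C)(O)/C=C/C(=O)/C(C(=O)N2CCCC2)=C\C1` has not yet been measured in this assay. It differs from compound 1 in one place: (pyrrolidin-1-yl)carbonyl in place of chloromethyl on a double-bonded ring carbon. For the measured compounds named here, no pair of measured compounds shows this same change, so the size of the step rests on expectation alone. Compound 1 is the only reference point for this change on the shared core. Compound 3 is expected to show a step from the value of compound 1 of a 3.8-fold higher number from compound 1 to compound 3 (0.59 log units; beyond the scatter), toward a weaker inhibitor. Compound 3 is therefore estimated at 1500 nM, within a range from 400 nM to 6000 nM.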

Compound 3, half-maximal inhibitory concentration: 15100 nM
The estimate for compound 3 lay 10-fold (1.00 log units) below the measured number, outside the stated range (above it).
By their numbers in this assay, from the lowest: compound 1; then compound 2; then compound 3.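

In this assay, the double-bonded ring carbon proves sensitive to the group it carries: (pyrrolidin-1-yl)carbonyl in place of chloromethyl gives a 39-fold higher number from compound 1 to compound 3 (1.59 log units; beyond the scatter), a large step toward a weaker inhibitor. For the compounds shown here, this is the first change at this carbon alone that can be read on the shared core, and it shows that chloromethyl cannot be exchanged here for this larger amide without a heavy loss of activity. The entering group brings a five-membered ring and a hydrogen-bond acceptor, but no measurement given here bears on why activity falls. Going by these compounds, it remains open whether the loss follows the pyrrolidine ring or the carbonyl, a question that a primary amide or a carboxylic acid at this carbon could help settle. On these data alone, it also remains open whether a plain methyl or a short amine-bearing chain here would stay close to compound 1 at 390 nM in activity.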